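A few compounds are considered here, and "the series" means these few. Any claim that something is new, unique, unknown or untested is made for them only; others in the source may bear on it.

Of the compounds shown here, two have been measured in an assay for positive allosteric modulation of metabotropic glutamate receptor 3 (Rattus norvegicus); a lower number here means that less compound is needed, a higher number that more compound is needed for the effect. Compound 1, `COc1cc(OCCCCOc2ccc(C(=O)CC(C)(C)C)c(O)c2C)cc(C(=O)O)c1`, gives 703 nM. Compound 2, `Cc1c(O[C@@H](C)COc2ccc(F)c(C(=O)O)c2)ccc(C(=O)CC(C)(C)C)c1O`, gives 1120 nM, the higher of the two numbers, although its gap to compound 1 lies within the scatter, so the two read as alike. Compound 3, `Cc1c(O[C@H](C)COc2ccc(F)c(C(=O)O)c2)ccc(C(=O)CC(C)(C)C)c1O`, shares every atom and bond with compound 2: the two compounds have the same atoms and bonds and differ only in configuration as drawn: 1 of 1 stereo elements differ; a stereocentre at a saturated chain carbon is drawn S in compound 2 and R in compound 3. Going by the values given here, no measured pair shows what such an inversion does in this assay, so neither direction is favoured. Compound 3 is expected to give 1100 nM, within 250 nM to 5000 nM. The expected step is a 1.0-fold lower number from compound 2 to compound 3 (0.01 log units; within the scatter), centred on no change beyond the scatter yet allowing a sizeable move either way.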

Compound 3, half-maximal effective concentration: 2410 nM
Compound 3: middle estimate off by 2.2-fold (0.34 log units), on the low side, within the range that was stated.
By their numbers in this assay, from the lowest: compounds 1 and 2 (each within the scatter of the next); then compound 3.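

In this assay, the stereocentre at this saturated chain carbon proves to matter: inverting it from S to R gives a 2.2-fold higher number from compound 2 to compound 3 (0.33 log units; beyond the scatter). Going by these compounds alone, this is the first measured inversion, and the step is modest in size. It can be assigned to configuration alone, because nothing else separates the pair: the fact that compounds 2 and 3 differ only in the configuration as drawn

The compounds shown leave open whether the S form keeps its edge in other members of the series, such as one carrying a chlorine in place of the fluorine. Also open, from the compounds shown here alone, is how an ethyl group in place of the methyl at this stereocentre would change the number.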